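Compound 4 and a Cell-Toxicity Limit

A few compounds are considered here, and "the series" means these few. Any claim that something is new, unique, unknown or untested is made for them only; others in the source may bear on it.

Of the compounds shown here, three sharing one core have been tested so far in an ADME assay on HEK293 cells (Homo sapiens) for cytotoxicity, with a stated time of 72 h (on this read-out higher numbers stand for an effect only at larger amounts of compound and lower numbers for an effect already at smaller amounts), for their effect on cells. Compound 1 (`C=C[C@@](C)(/C=C/c1ccc(OC)cc1)CCC=C(C)C`) gives > 36600 nM as a limit of the assay and not a number. Compound 2 (`C=C[C@@](C)(/C=C/c1ccc(OS(=O)(=O)C(F)(F)F)cc1)CCC=C(C)C`) gives > 36600 nM as a limit as well. On these data alone, compound 3 (`C=C[C@@](C)(/C=C/c1ccc(Nc2ccc(Cl)cc2)cc1)CCC=C(C)C`) gives > 36600 nM as a limit too, so its exact standing is unknown.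

Compound 4 (`C=C[C@@](C)(/C=C/c1ccc(-c2ccc(F)cc2)cc1)CCC=C(C)C`) has not yet been measured. It carries 4-fluorophenyl in place of (4-chlorophenyl)amino on an aromatic carbon, para to a large group, and the full change is 4-fluorophenyl in place of (4-chlorophenyl)amino on an aromatic carbon in structural terms.

For the measured compounds named here, three measured steps bear on this. Putting (4-chlorophenyl)amino in place of methoxy gave a step that the two limits leave unreadable from compound 1 to compound 3 as its result. Putting it in place of ((trifluoromethyl)sulfonyl)oxy gave a step that the two limits leave unreadable from compound 2 to compound 3 as its result. Exchanging methyl for (trifluoromethyl)sulfonyl on the oxygen gave a step that the two limits leave unreadable from compound 1 to compound 2 as its result. The series shows the limit of > 36600 nM in this assay, at which 3 of the 3 values shown sit, and offers no readable step size.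

No measurable step in either direction is therefore expected in this assay for this change. The estimated change is a step that the limit leaves unreadable from compound 3 to compound 4 on this expectation. For compound 4 the estimated value is 50000 nM with an expected range from 30000 nM to 100000 nM and a limit is the most likely report.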

Compound 4, half-maximal effective concentration: > 36600 nM
Compound 4: a limit, no number; the forecaster's own chance of this, stated with the estimate: 85%; the middle value is on the limit's open side.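

Compound 4 also gives a limit of the assay and not a number, so no step from compound 1, compound 2 or compound 3 to compound 4 can be read: the limit of > 36600 nM in this assay, at which 4 of the 4 values shown sit.

The compounds shown leave open at what concentration any of these four would produce an effect in this assay and whether exchanging the group on the aromatic carbon changes that concentration.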